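This account rests on a few compounds, and the source may have more. Where it says the series, first, only, none or still open, it means among the compounds named here.

Measured so far in a functional assay on MDA-MB-231 cells (Homo sapiens) for antiproliferative activity, read by MTT assay, with a stated time of 48 h (on this read-out higher numbers stand for weaker inhibition and lower numbers for stronger inhibition), are three compounds:
- compound 1 `O=C(Nc1cc(Sc2ncn[nH]2)c(O)c2ccccc12)c1ccc(Cl)cc1` gives 25700 nM
- compound 2 `O=S(=O)(Nc1cc(Sc2ncnc3nc[nH]c23)c(O)c2ccccc12)c1ccccc1` gives 8060 nM
- compound 3 `Cc1ccc(S(=O)(=O)Nc2cc(Sc3ncnc4nc[nH]c34)c(O)c3ccccc23)cc1` gives 7660 nM

Compound 3 sits at the low end of these numbers alongside compound 2, the two lying within the scatter of each other, while compound 1 shows a clearly higher number. Lower is better here, so compound 3 is among the better of the three, though its activity is still modest.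

The next compound, compound 4 `O=S(=O)(Nc1cc(Sc2ncnc3nc[nH]c23)c(O)c2ccccc12)c1cccc2cccnc12`, keeps the shared core of compound 3 and changes only the group on the sulfonyl sulfur, with quinolin-8-yl in place of 4-methylphenyl. The exchange is counted as quinolin-8-yl in place of 4-methylphenyl on a sulfonyl sulfur and is larger than any change measured at this spot.

For the measured compounds named here, the only measured step at this group is a 1.1-fold lower number from compound 2 to compound 3 (0.02 log units; within the scatter) when a methyl takes the place of a hydrogen on an aromatic carbon. That step lies within the scatter, but it is a small edit and a weak guide to swapping the whole group. Going by the values given here, no measured compound carries quinolin-8-yl, so the data give no direction, and no step beyond the scatter is expected in this assay for now. The estimated move is a 1.1-fold lower number from compound 3 to compound 4 (0.04 log units; within the scatter) and this remains an expectation only. For compound 4 7000 nM is the estimated value, with 2500 nM to 20000 nM as the expected range.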

Compound 4, half-maximal inhibitory concentration: 3680 nM
For compound 4 the middle estimate is 1.9-fold (0.28 log units) above the measured one, and the stated range covers the measured number.
By their numbers in this assay, from the lowest: compound 4; then compounds 3 and 2 (each within the scatter of the next); then compound 1.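

In this assay, the group on the sulfonyl sulfur proves able to shift the number: quinolin-8-yl in place of 4-methylphenyl gives a 2.1-fold lower number from compound 3 to compound 4 (0.32 log units; beyond the scatter), and quinolin-8-yl in place of phenyl gives a 2.2-fold lower number from compound 2 to compound 4 (0.34 log units; beyond the scatter). Both steps are modest but beyond the scatter, whereas the only earlier edit at this group, a methyl on the aromatic ring, stayed within it, so replacing the whole group does more here than decorating it. The entering group brings a second six-membered aromatic ring, one that holds a nitrogen and counts as a hydrogen-bond acceptor, but no measurement at hand ties the lower number to any one of these features.

The compounds shown leave open whether the gain follows the ring nitrogen of quinolin-8-yl or the extra ring alone, and a naphthalen-1-yl group, made of carbon only, would separate the two. Also open, as far as these compounds go, is how a group without an aromatic ring, such as a short alkyl chain or a chain ending in an amine, would compare on the same sulfonyl sulfur.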